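This account rests on a few compounds, and the source may have more. Where it says the series, first, only, none or still open, it means among the compounds named here.

Three compounds share a core that carries a trifluoromethyl ketone on one side and an aryl group on the other. In an assay for inhibition of histone deacetylase 4 (Homo sapiens) (a higher number here means a weaker inhibitor, a lower number a stronger inhibitor), compound 1 `O=C(c1ccc(-c2nc(-c3ccc(C(F)(F)F)cc3)no2)s1)C(F)(F)F` gives 200 nM. Compound 2 `O=C(c1ccc(-c2nnc(-c3ccccc3)o2)s1)C(F)(F)F` gives 420 nM in this assay. Compound 3 `Cc1ccc(-c2noc(-c3ccc(C(=O)C(F)(F)F)s3)n2)cc1` gives 110 nM in this assay, the lowest of the three numbers; its gap to compound 1 is within the scatter, while its gap to compound 2 is beyond it. Within the data shown here, the only single-point step among the measured compounds, a 1.8-fold lower number from compound 1 to compound 3 (0.26 log units; within the scatter), concerns the group on the aryl ring and stayed within the scatter. Compound 4 `O=C(c1ccc(-c2nc(-c3ccccn3)no2)s1)C(F)(F)F` differs from compound 3 by pyridin-2-yl in place of 4-methylphenyl on an aromatic carbon. Among the measured compounds shown here, no measured step covers the exchange of one aryl ring for another, so the one step that bears on this region shows only that a change on the aryl group need not move this assay beyond the scatter. Compound 4 is therefore expected to stay close to compound 3, with the step of a 1.8-fold higher number from compound 3 to compound 4 (0.26 log units; within the scatter) expected to lie within the scatter. Compound 4 is estimated at 200 nM, with a range from 70 nM to 600 nM.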

Compound 4, half-maximal inhibitory concentration: 90 nM
The estimate for compound 4 lay 2.2-fold (0.35 log units) above the measured number; measured number inside the range.
By their numbers in this assay, from the lowest: compounds 4, 3 and 1 (each within the scatter of the next, the first and the last beyond it); then compound 2.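

In this assay, pyridin-2-yl in place of 4-methylphenyl gives a 1.2-fold lower number from compound 3 to compound 4 (0.09 log units; within the scatter). The earlier step changed only a group on the aryl ring, whereas this one exchanges the ring itself at the carbon between two ring nitrogen atoms, bringing in a ring nitrogen and a hydrogen-bond acceptor while the number stays within the scatter. No measured evidence bears on why these two aryl groups give such similar numbers.

The compounds shown leave open whether this position holds its number with something other than a six-membered aromatic ring, such as a morpholine, a primary amine or a longer alkyl chain. Also open, as far as these compounds go, is how plain phenyl on the core of compound 3 would compare with pyridin-2-yl.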